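Aryl swap on two piperazine-linked bicyclic imide cores

The compounds below may be only part of what the source reports. "The series", "measured", "known", "first", "only" and "open" are said of these compounds alone.

Compound 1 `COc1ccccc1N1CCN(CN2C(=O)C3CCCN3C2=O)CC1` and compound 2 `O=C1C2CCCN2C(=O)N1CN1CCN(c2cccc(Cl)c2)CC1` share one core; compound 3 `COc1ccccc1N1CCN(CN2C(=O)C3CCCCN3C2=O)CC1` and compound 4 `O=C1C2CCCCN2C(=O)N1CN1CCN(c2cccc(Cl)c2)CC1` share another. The difference between the two cores is not broken down here. In an assay on isolated protein for binding affinity to Adrenergic receptor alpha-1 (Rattus norvegicus), read by radioligand binding (on this read-out higher numbers stand for weaker inhibition and lower numbers for stronger inhibition), compound 1 gives 500 nM, and in the same assay compound 2 gives 292 nM. The change between them, (3-chlorophenyl in place of 2-methoxyphenyl on an amine nitrogen in a ring), gave a 1.7-fold lower number from compound 1 to compound 2 (0.23 log units; within the scatter). For compound 3 this assay reports only a limit, > 1000 nM, which is the situation described by the limit of > 1000 nM in this assay, at which 1 of the 3 values shown sits. Compound 4 is not yet measured; it arises from compound 3 by the same change, (3-chlorophenyl in place of 2-methoxyphenyl on an amine nitrogen in a ring), at the same place. For compound 4 the expected step is a step that the limit leaves unreadable from compound 3 to compound 4, resting on the measured step of a 1.7-fold lower number from compound 1 to compound 2 (0.23 log units; within the scatter) on the other core. Compound 4 is thus estimated at 1200 nM, probably between 400 nM and 4000 nM, with a real chance that this assay again reports only a limit.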

Compound 4, inhibition constant: 135 nM
Beside the measured number, compound 4's estimate is 8.9-fold (0.95 log units) above it; measured number below the stated range.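

In this assay the change to 3-chlorophenyl gives an at least 7.4-fold lower number from compound 3 to compound 4 (0.86 log units; beyond the scatter), so on these two cores it does not carry over at one size: the same change on two cores in this assay, a 1.7-fold lower number (0.23 log units; within the scatter) from compound 1 to compound 2 and an at least 7.4-fold lower number (0.86 log units; beyond the scatter) from compound 3 to compound 4, at least 4.3-fold (0.63 log units) apart, beyond the scatter of two such steps. From the compounds shown here alone, compound 3 stands at a limit, so this step is a minimum and its true size remains unknown: the limit of > 1000 nM in this assay, at which 1 of the 4 values shown sits. For the compounds shown here, with only two pairs, the result shows that step size can differ with the core, but it does not explain the difference or predict the step on any further core.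

Still open, going by these compounds, is whether the same gap appears with a pyridyl ring on the amine nitrogen in place of 3-chlorophenyl. Also open, on these data alone, is whether it survives a longer chain in place of the present link to the core.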